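Thiosemicarbazones on HeLa Cells: Pyridine Swap Toward Compound 3

The compounds below may be only part of what the source reports. "The series", "measured", "known", "first", "only" and "open" are said of these compounds alone.

Among the measured compounds shown here, compound 2 `N/C(=N\NC(=S)N1CCN(c2ccccn2)CC1)c1ccc(F)cn1` gives the higher of the two numbers measured so far: in a functional assay on HeLa cells (Homo sapiens) for cytotoxicity, read by MTT assay, with a stated time of 72 h, tested at 30 uM (on this read-out lower numbers stand for less inhibition of growth and higher numbers for more inhibition of growth at the one concentration tested), compound 2 reaches 87%, while compound 1 `Cc1ccnc(/C(N)=N/NC(=S)N2CCCCCC2)c1` gives 69.9% in this assay, a gap beyond the usual scatter. Compound 3 `Cc1cccc(/C(N)=N/NC(=S)N2CCN(c3ccccn3)CC2)n1` has not yet been measured; it differs from compound 2 by 6-methylpyridin-2-yl in place of 5-fluoropyridin-2-yl on a carbon with a double bond to nitrogen. For the measured compounds named here, with no measured step of this kind available, the author expects for compound 3 a change in this assay of a number 9 percentage points lower from compound 2 to compound 3 (within the scatter), not beyond the scatter, leaning slightly lower. Compound 3 is estimated at 78%, within 60% to 92%.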

Compound 3, percent growth inhibition at one concentration: 86.3%
The estimate for compound 3 lay 8.3 percentage points below the measured number, within the range that was stated.
By their numbers in this assay, from the lowest: compound 1; then compounds 3 and 2 (each within the scatter of the next).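

In this assay, 6-methylpyridin-2-yl in place of 5-fluoropyridin-2-yl on a carbon with a double bond to nitrogen gives a number 0.7 percentage points lower from compound 2 to compound 3 (within the scatter). Among the compounds shown here, this is the first step read at this place, and at the one concentration tested the read-out does not separate the two groups. Nothing available bears on why they read alike. From the compounds shown here alone, whether a pyridin-2-yl ring carrying an amine or a carboxylic acid would read alike at this place stays open. So does whether the same exchange would give a similar step on the core of compound 1.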